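Allyl Sulfanyl Chain Shortened to Ethynyl Sulfanyl

The source may hold more compounds than are shown below. What is called first, only, known or untested is meant among the compounds shown, and "the series" means these compounds.

Measured compounds in a toxicity assay on GES1 cells (Homo sapiens) for inhibition, read by MTT assay, with a stated time of 72 h; a lower number here means a stronger inhibitor, a higher number a weaker inhibitor:
compound 1, `Cc1cc(N2CC[C@@H](C)[C@@H](N(C)c3ncnc4[nH]ccc34)C2)n2nc(SCc3ccccc3)nc2n1`, gives 67200 nM
compound 2, `Cc1cc(N2CC[C@@H](C)[C@@H](N(C)c3ncnc4[nH]ccc34)C2)n2nc(SCCc3ccccc3)nc2n1`, gives 66200 nM
compound 3, `C=CCSc1nc2nc(C)cc(N3CC[C@@H](C)[C@@H](N(C)c4ncnc5[nH]ccc45)C3)n2n1`, gives > 100000 nM

For compound 3 only a limit is known, (the limit of > 100000 nM in this assay, at which 1 of the 3 values shown sits); it is a floor of this assay, not a number. Compound 1 and compound 2 sit near each other: a 1.0-fold lower number from compound 1 to compound 2 (0.01 log units; within the scatter). The two steps into compound 3 run the other way, an at least 1.4-fold higher number from compound 1 to compound 3 (0.17 log units; that floor lies within the scatter) and an at least 1.5-fold higher number from compound 2 to compound 3 (0.17 log units; that floor lies within the scatter), but both have floors within the scatter, so the three compounds cannot be ranked.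

Compound 4, `C#CSc1nc2nc(C)cc(N3CC[C@@H](C)[C@@H](N(C)c4ncnc5[nH]ccc45)C3)n2n1`, differs from compound 3 by ethynyl in place of allyl on a sulfur. For the measured compounds named here, no measured step touches an allylsulfanyl to ethynylsulfanyl change; the three known steps swap phenyl, benzyl and vinyl on the saturated chain carbon bound to sulfur and all stay within scatter. Going by the values given here, with no step showing a shift beyond scatter, compound 4 is expected to stay near compound 3, with a number no higher from compound 3 to compound 4 (the limit leaves the size open). Compound 4 is therefore estimated at 100000 nM, between 50000 nM and 200000 nM, most likely reported again only as a limit.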

Compound 4, half-maximal inhibitory concentration: > 100000 nM
Compound 4 ended at the assay's limit; the forecaster's own chance of this, stated with the estimate: 70%; the middle value lies on the limit itself.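

In this assay, a second small unsaturated group on the sulfur, ethynyl in place of allyl, again gives a limit of the assay rather than a number, now for compound 4: the limit of > 100000 nM in this assay, at which 2 of the 4 values shown sit. Both compound 3 and compound 4 are known only as limits, so the step between them cannot be read and the change from allylsulfanyl to ethynylsulfanyl has no measurable size here. The comparisons with the phenyl-bearing chains give an at least 1.5-fold higher number from compound 2 to compound 4 (0.17 log units; that floor lies within the scatter) and an at least 1.4-fold higher number from compound 1 to compound 4 (0.17 log units; that floor lies within the scatter), so neither step separates compound 4 from the compounds that carry those chains.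

From the compounds shown here alone, whether compound 3 and compound 4 differ at all stays open, as does whether either truly lies apart from compound 1 and compound 2. The compounds shown also leave open how an amine, a carboxylic acid or a longer alkyl chain on the sulfur would read in this assay.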